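The source may hold more compounds than are shown below. What is called first, only, known or untested is meant among the compounds shown, and "the series" means these compounds.

Measured in an ADME assay on CCRF-CEM cells (Homo sapiens) for cytotoxicity; a higher number here means that more compound is tolerated, a lower number that less compound is tolerated:
compound 1 `COC(=O)CNC(=O)c1cnc2ccccc2c1Cl`: > 100 uM, a limit of the assay.
compound 2 `COC(=O)[C@H](C)NC(=O)c1cnc2ccccc2c1Cl`: 81.3 uM.
compound 3 `COC(=O)[C@H](CC(C)C)NC(=O)c1cnc2ccccc2c1Cl`: 49.1 uM.

Compound 3 holds the lowest of the two numbers; the nearest is a 1.7-fold lower number from compound 2 to compound 3 (0.22 log units; within the scatter), within the scatter. Compound 1 sits at the limit of > 100 uM in this assay, at which 1 of the 3 values shown sits.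

Compound 4 `COC(=O)[C@H](CSC)NC(=O)c1cnc2ccccc2c1Cl` differs from compound 3 by methylsulfanyl in place of isopropyl on a saturated chain carbon, two bonds along the chain from an amide-type nitrogen and a carbonyl carbon. The step that bears on this place is a 1.7-fold lower number from compound 2 to compound 3 (0.22 log units; within the scatter), and the wider steps are an at least 1.2-fold lower number from compound 1 to compound 2 (0.08 log units; that floor lies within the scatter) and an at least 2.0-fold lower number from compound 1 to compound 3 (0.30 log units; that floor lies within the scatter), each a floor. All lie within the scatter, so in this assay no step beyond the scatter is expected for compound 4, and it is estimated at a 1.1-fold higher number from compound 3 to compound 4 (0.05 log units; within the scatter). Compound 4 is expected near 55 uM, between 30 uM and 100 uM.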

Compound 4, half-maximal toxic concentration: 68.4 uM
Estimate against measurement, compound 4: 1.2-fold (0.09 log units) below, and the stated range covers the measured number.
By their numbers in this assay, from the lowest: compounds 3, 4 and 2 (each within the scatter of the next). At a limit, above all of these: compound 1.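

In this assay, methylsulfanyl at this place, on a saturated chain carbon two bonds along the chain from an amide-type nitrogen and a carbonyl carbon, stays within the scatter of isopropyl: a 1.4-fold higher number from compound 3 to compound 4 (0.14 log units; within the scatter). Set against hydrogen at the same place, it also stays within the scatter: a 1.2-fold lower number from compound 2 to compound 4 (0.08 log units; within the scatter). The comparison with the unbranched chain gives only a floor, an at least 1.4-fold lower number from compound 1 to compound 4 (0.16 log units; that floor lies within the scatter), and the value it starts from is a limit of the assay: the limit of > 100 uM in this assay, at which 1 of the 4 values shown sits.

As far as these compounds go, whether an amine, a carboxylic acid or a longer chain here would give a step beyond the scatter remains open.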